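Aryl Substituent Swaps on a Dienone Cytotoxicity Series

The source may report more compounds than this note shows. Statements on the series, on what has been measured and on what is new or still open speak of the compounds shown alone.

Measured compounds:
Compound 1 `CC1=C(/C=C/C(=O)/C=C/c2ccc(C#N)cc2)C(C)(C)CCC1` — 22200 nM
Compound 2 `CC1=C(/C=C/C(=O)/C=C/c2ccc(C)cc2)C(C)(C)CCC1` — 20400 nM
Compound 3 `CC1=C(/C=C/C(=O)/C=C/c2ccc([N+](=O)[O-])cc2)C(C)(C)CCC1` — 28700 nM

All three share one core and differ only in the group carried on the aromatic ring. In a functional assay on HeLa cells (Homo sapiens) for cytotoxicity, read by sulforhodamine B assay, with a stated time of 48 h (on this read-out lower numbers stand for stronger inhibition and higher numbers for weaker inhibition), compound 2 gives the lowest of the three numbers, but its steps to the others, a 1.4-fold higher number from compound 2 to compound 3 (0.15 log units; within the scatter) and the reverse of a 1.1-fold lower number from compound 1 to compound 2 (0.04 log units; within the scatter), stay within the scatter, so no order among the three can be claimed. The third step, a 1.3-fold higher number from compound 1 to compound 3 (0.11 log units; within the scatter), is likewise within the scatter.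

Compound 4 `CC1=C(/C=C/C(=O)/C=C/c2ccccc2Br)C(C)(C)CCC1` is not yet measured. It differs from compound 2 by 2-bromophenyl in place of 4-methylphenyl on a double-bonded chain carbon bound to a double-bonded chain carbon. For the measured compounds named here, none of the measured steps exchange bromine or move a substituent to the 2-position of the phenyl ring, so no step bears on this change directly. What the measured steps do show is that exchanging cyano, methyl and nitro on that aromatic ring left this assay unmoved beyond the scatter in every case. On that basis no step beyond the scatter is expected, with a 1.0-fold higher number from compound 2 to compound 4 (0.01 log units; within the scatter) as the estimated step from compound 2 to compound 4. Compound 4 is therefore estimated at 21000 nM, with a range of 9000 nM to 48000 nM.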

Compound 4, half-maximal inhibitory concentration: 57900 nM
Compound 4: the middle estimate sits 2.8-fold (0.44 log units) below what was measured; the whole stated range lies below it.
By their numbers in this assay, from the lowest: compounds 2, 1, 3 and 4 (each within the scatter of the next, the first and the last beyond it).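

In this assay, a 2.8-fold higher number from compound 2 to compound 4 (0.45 log units; beyond the scatter), a modest step but the only one in this series printed as beyond the scatter, and it goes towards weaker inhibition. The aromatic group on this double-bonded chain carbon bound to a double-bonded chain carbon therefore does not tolerate every exchange, as the swaps among cyano, methyl and nitro alone might have suggested. Replacing 4-methylphenyl with 2-bromophenyl changes both the substituent and where it sits on the ring, and nothing shown separates these two changes or explains the step.

Left open is whether a methyl group in the place of the bromine in 2-bromophenyl, or a bromine in the place of the methyl in 4-methylphenyl, would give a number closer to that of compound 4 or to that of compound 2. Also open, going by these compounds, is how an amine, a carboxylic acid or a longer chain on the aromatic ring would read in this assay, and whether any of these would move the number in the opposite direction.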